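This account rests on a few compounds, and the source may have more. Where it says the series, first, only, none or still open, it means among the compounds named here.

Of the compounds shown here, three have so far been measured in a functional assay on HCT-116 cells (Homo sapiens) for inhibition, read by MTT assay, with a stated time of 2 days, tested at 10 uM; a higher number here means more inhibition at the concentration tested (going by the name of the read-out), a lower number less inhibition. Compound 1 `O=C(OCCCc1ccccc1)c1cc(-n2cc(-c3cccc(O)c3)nn2)ccc1O` gives 11%, and compound 3 `COC(=O)c1cc(-n2cc(-c3cc(O)ccc3O)nn2)ccc1O` gives 15%. Compound 2 `COc1ccc(OC)c(-c2cn(-c3ccc(O)c(C(=O)Nc4cccc(C(F)(F)F)c4)c3)nn2)c1` gives 46%, the highest of the three numbers; its nearest neighbour is compound 3, a number beyond the scatter below it, while compound 1 lies further below, also beyond the scatter. Compound 4 `COc1ccccc1-c1cn(-c2ccc(O)c(C(=O)Nc3cccc(C(F)(F)F)c3)c2)nn1` has not been measured in this assay. It differs from compound 2 in one place: hydrogen in place of methoxy on an aromatic carbon. Within the data shown here, no measured pair here differs in a single place, so the size of such a step is unknown from these data. With only a methoxy leaving and hydrogen entering, a small step is expected, a number 6 percentage points lower from compound 2 to compound 4 (within the scatter), downward or none beyond the scatter. Compound 4 is therefore estimated at 40%, with a range from 18% to 60%.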

Compound 4, a percentage reported as inhibition, at one concentration (the size of the read-out at that concentration, not a potency): 61%
Estimate against measurement, compound 4: 21 percentage points below; the whole stated range lies below it.
By their numbers in this assay, from the lowest: compounds 1 and 3 (each within the scatter of the next); then compound 2; then compound 4.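

In this assay, the change from 2,5-dimethoxyphenyl to 2-methoxyphenyl gives a number 15 percentage points higher from compound 2 to compound 4 (beyond the scatter) and is the only single-place step among these compounds. It shows that, at this position on the aromatic carbon, the methoxy is not needed to retain inhibition at the concentration tested, and that hydrogen gives the higher number. Nothing shown here explains this rise.

Going by these compounds, it remains open how a fluorine or an amine at this position would compare with hydrogen. On these data alone, the effect of removing the remaining methoxy also remains unknown.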